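Methoxyphenyl Exchanged for Fluoro-Methylphenyl: Solubility Outlook

The source may report more compounds than this note shows. Statements on the series, on what has been measured and on what is new or still open speak of the compounds shown alone.

Compound 2 `COc1ccc(-c2cnn3c(NCc4ccccn4)cc(C)nc23)cc1` stands in a physicochemical assay for solubility, read by HPLC, using the shake flask method, measured as kinetic solubility, with a stated time of 2 h, at pH 7.4 (a lower number here means a less soluble compound, a higher number a more soluble compound), at a limit of the assay: compound 2 gives < 5000 nM, a limit rather than a number. Compound 1 `COc1ccc(-c2c(C)nn3c(NCc4ccccn4)cc(C)nc23)cc1` likewise reaches only a limit in this assay, < 5000 nM. The step that the two limits leave unreadable from compound 1 to compound 2 is therefore not readable, because the limit of < 5000 nM in this assay, at which 2 of the 3 values shown sit, holds both ends of it. Compound 3 `Cc1cc(NCc2nccn2C)n2nc(C)cc2n1` gives 182000 nM in this assay. Compound 4 `Cc1cc(NCc2ccccn2)n2ncc(-c3ccc(F)cc3C)c2n1` differs from compound 2 by 4-fluoro-2-methylphenyl in place of 4-methoxyphenyl on an aromatic carbon. For the measured compounds named here, no measured step concerns this change, so the measured compounds give no size for it; with compound 2 at a limit, the step is expected to be a step that the limit leaves unreadable from compound 2 to compound 4 and likely to remain unreadable. Compound 4 is expected to give 3000 nM in this assay, between 500 nM and 12000 nM.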

Compound 4, solubility: 42300 nM
Compound 4: middle estimate off by 14-fold (1.15 log units), on the low side; measured number above the stated range.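

In this assay, the exchange of 4-methoxyphenyl for 4-fluoro-2-methylphenyl on an aromatic carbon of the five-membered ring gives a readable step where the earlier pair gave none: an at least 8.4-fold higher number from compound 2 to compound 4 (0.92 log units; beyond the scatter). For the compounds shown here, with this change, compound 4 is the first compound carrying the pyridine-free-of-limit reading among those sharing the core of compound 2. Compound 2 stands at a limit, so the step gives only a lower bound on the size of the change: the limit of < 5000 nM in this assay, at which 2 of the 4 values shown sit.

The compounds shown do not separate the part played by the fluorine from that of the methyl group, or from the loss of the methoxy group. From the compounds shown here alone, whether an amine or a carboxylic acid on this phenyl ring would give a higher number remains open.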